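The source may hold more compounds than are shown below. What is called first, only, known or untested is meant among the compounds shown, and "the series" means these compounds.

In the series described here, the read-out is a functional assay on HT29-AK cells (Homo sapiens) for cytotoxicity, read by MTT assay, with a stated time of 48 h; on this read-out higher numbers stand for weaker inhibition and lower numbers for stronger inhibition. Compound 1 has the structure `Fc1cccc(-c2nc(Nc3ccccc3)c3ccccc3n2)c1`. In this assay compound 1 gives > 50000 nM, which is a limit of the assay and not a number. Compound 2 has the structure `Fc1cccc(Nc2nc(-c3cccc(F)c3)nc3ccc(F)cc23)c1`. In this assay compound 2 gives > 50000 nM, again a limit rather than a number. Compound 2 therefore stands at the limit of > 50000 nM in this assay, at which 2 of the 2 values shown sit, so no ordering between the two measured compounds can be drawn from what is known.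

Compound 3, with the structure `Fc1cccc(-c2nc(Nc3ccccc3Br)c3cc(F)ccc3n2)c1`, has not yet been measured. It differs from compound 2 by 2-bromophenyl in place of 3-fluorophenyl on a nitrogen on an aromatic ring. Going by the values given here, no measured pair of compounds shows what such a change does in this assay, so there is no known step to lean on. Since both measured values sit at the limit, the expectation for the step from compound 2 to compound 3 is a step that the limit leaves unreadable from compound 2 to compound 3, that is, none beyond the scatter. For compound 3 the estimate in this assay is 60000 nM, with a range from 15000 nM to 250000 nM, and it is likely that the assay will again report only a limit.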

Compound 3, half-maximal inhibitory concentration: > 50000 nM
Compound 3 ended at the assay's limit; the forecaster's own chance of this, stated with the estimate: 75%; the middle value does not contradict the limit.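

In this assay compound 3 gives > 50000 nM, which is a limit of the assay and not a number. Going by these compounds alone, compound 2 sits at the same limit, so no step from compound 2 to compound 3 can be read. The compounds shown leave open what swapping 3-fluorophenyl for 2-bromophenyl does, since none yields an actual number: the limit of > 50000 nM in this assay, at which 3 of the 3 values shown sit.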